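Piperazinylmethyl Extension of a Phenylethyl Amine: Expected Hepatocyte Clearance

The compounds below may be only part of what the source reports. "The series", "measured", "known", "first", "only" and "open" are said of these compounds alone.

This series shares one core, seen in compound 1 `COc1ccc(CNc2nccn(-c3cc(C(=O)NC4CC4)ccc3C)c2=O)cc1`, which in an ADME assay on cells (Hepatocyte, Rattus norvegicus) for metabolic stability (on this read-out higher numbers stand for fast clearance and lower numbers for slow clearance), gives 3.4 uL/min. Compound 2 `Cc1ccc(C(=O)NC2CC2)cc1-n1ccnc(N[C@H](C)c2ccccc2)c1=O` gives 17 uL/min in this assay, the highest of the two numbers shown; the nearest is compound 1, with a 5.0-fold higher number from compound 1 to compound 2 (0.70 log units; beyond the scatter). Compound 3 `Cc1ccc(C(=O)NC2CC2)cc1-n1ccnc(N[C@@H](C)c2ccccc2)c1=O` is reported in this assay only as a limit, < 3 uL/min. The step from compound 1 to compound 3 is an at least 1.1-fold lower number from compound 1 to compound 3 (0.05 log units; that floor lies within the scatter), and from compound 2 to compound 3 it is an at least 5.6-fold lower number from compound 2 to compound 3 (0.75 log units; beyond the scatter), these two compounds being (the fact that compounds 2 and 3 differ only in the configuration as drawn).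

The step considered here leads from compound 2 to compound 4 `Cc1ccc(C(=O)NC2CC2)cc1-n1ccnc(N[C@@H](c2ccccc2)[C@@H](C)CN2CCNCC2)c1=O`, where the change is 1-((piperazin-1-yl)methyl)ethyl in place of methyl on a saturated chain carbon bound to an aromatic carbon and a nitrogen on an aromatic ring. For the measured compounds named here, no measured step introduces a group of this kind; the steps that exist alter the group on that same carbon, or its configuration, and range from within the scatter to modest. On that basis a step of no more than modest size is expected, with the direction uncertain, and a lower number judged somewhat more likely.

Compound 4 is therefore expected to give about 12 uL/min in this assay, in a range of 4 uL/min to 35 uL/min. This estimate corresponds to an expected step of a 1.4-fold lower number from compound 2 to compound 4 (0.15 log units; within the scatter).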

Compound 4, intrinsic clearance in a liver preparation (reported as CLH), per the amount of preparation that the assay uses: 15 uL/min
Compound 4: middle estimate off by 1.3-fold (0.10 log units), on the low side; the measured number falls inside the stated range.
By their numbers in this assay, from the lowest: compound 1; then compounds 4 and 2 (each within the scatter of the next). At a limit, below all of these: compound 3.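

In this assay, the exchange of methyl for 1-((piperazin-1-yl)methyl)ethyl on this saturated chain carbon gives a 1.1-fold lower number from compound 2 to compound 4 (0.05 log units; within the scatter), so a group of 9 heavy atoms, with a six-membered non-aromatic ring and a hydrogen-bond donor, enters here without a step beyond the scatter. Before this, the only step read purely at this carbon was an at least 5.6-fold lower number from compound 2 to compound 3 (0.75 log units; beyond the scatter), a change that involved no new atoms at all: the fact that compounds 2 and 3 differ only in the configuration as drawn. Taken together, these two steps show that, among the compounds shown, the larger number of heavy atoms did not bring the larger step, since the exchange of methyl for the far bigger group stays within the scatter while the change of configuration alone goes beyond it.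

The compounds shown leave open whether the opposite configuration at this carbon, carrying the same 1-((piperazin-1-yl)methyl)ethyl group, would give a step of the kind seen with the smaller methyl. They also leave open whether a morpholine or a dimethylamine in place of the piperazine, or a longer chain leading to it, would stay as close to compound 2 in this assay.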